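The compounds below may be only part of what the source reports. "The series", "measured", "known", "first", "only" and "open" are said of these compounds alone.

In an ADME assay on RAW264.7 cells (Mus musculus) for cytotoxicity, read by MTT assay, with a stated time of 24 h, in the presence of a further agent that is not named here (a higher number here means a weaker inhibitor, a lower number a stronger inhibitor), compound 1 (`COc1ccc(C(O)C2OC(=O)c3c(OC)cc(OC)cc32)cc1`) gives > 40000 nM as a limit of the assay and not a number. Compound 2 (`COc1cc(OC)c2c(c1)/C(=C/c1ccc(OCc3ccccc3)cc1)OC2=O`) gives > 40000 nM as a limit too, so it has no numeric position in the series. For the measured compounds named here, the readings so far amount to the limit of > 40000 nM in this assay, at which 2 of the 2 values shown sit, and offer no measured step between compounds.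

Compound 3 (`COc1cc(OC)c2c(c1)/C(=C/c1ccc(OCc3ccc(F)cc3)cc1)OC2=O`) carries the change fluoro in place of hydrogen on an aromatic carbon on the benzyloxy group of compound 2, which becomes (4-fluorobenzyl)oxy. This places fluoro in place of hydrogen on an aromatic carbon, para to a large group. Going by the values given here, no measured step covers this change. The expectation rests on compound 2 alone, whose reading > 40000 nM is a limit. The expected step of a number no higher from compound 2 to compound 3 (the limit leaves the size open) is estimated to stay within the usual scatter, with no direction expected in this assay and another limit reading as the likeliest result. For compound 3 the expected value is 40000 nM (estimated range 20000 nM to 60000 nM).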

Compound 3, half-maximal inhibitory concentration: > 40000 nM
Compound 3 ended at the assay's limit; the forecaster's own chance of this, stated with the estimate: 85%; the middle value sits exactly at the limit.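

No step can be read from compound 2 to compound 3: both readings are limits of the assay and not numbers, so what fluoro in place of hydrogen does on the benzyloxy group stays unreadable. The compounds shown leave open whether any change to the shared core gives a numeric reading in this assay at all.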